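The compounds below may be only part of what the source reports. "The series", "measured", "known", "first", "only" and "open" are said of these compounds alone.

This account follows compound 3 (`O=C(O)c1cc(-c2cc[nH]n2)ccc1O`) into compound 4 (`O=C(O)c1cc(-n2cnnc2)ccc1O`) in a functional assay on the whole organism for inhibition, with Rattus norvegicus as the target, read by paw edema; on this read-out higher numbers stand for an effect only at larger amounts of compound and lower numbers for an effect already at smaller amounts. Compound 3 reaches only a limit of the assay in this assay, > 250 mg/kg, rather than a number. Its neighbours set the frame. Compound 1 (`O=C(O)c1cc(-c2csnn2)ccc1O`) likewise gives only a limit in this assay, > 200 mg/kg. Compound 2 (`O=C(O)c1cc(-n2cccn2)ccc1O`) gives a number in this assay, 200 mg/kg. As far as these compounds go, the step of an at least 1.2-fold higher number from compound 2 to compound 3 (0.09 log units; that floor lies within the scatter) bears most on the change at hand, since it too exchanges the manner in which the five-membered ring is attached; the step that the two limits leave unreadable from compound 1 to compound 3 adds nothing readable, and a number no higher from compound 1 to compound 2 (the limit leaves the size open) is equally open. The change itself: 4H-1,2,4-triazol-4-yl in place of 1H-pyrazol-3-yl on an aromatic carbon. Compound 4 thus carries a ring attached through a nitrogen, as compound 2 does, but with three hetero atoms and no hydrogen-bond donor. Compound 2 stands at 200 mg/kg in this assay. Compound 3 reaches only a limit of the assay in this assay, > 250 mg/kg. For compound 4 the step of an at least 1.1-fold lower number from compound 3 to compound 4 (0.05 log units; that floor lies within the scatter) is therefore expected to stay within the scatter. The estimate for compound 4 is 220 mg/kg, with a range from 120 mg/kg to 400 mg/kg, and a fair chance that this assay again reports only a limit.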

Compound 4, dose for half-maximal effect: > 250 mg/kg
Compound 4: no number, only a limit; the forecaster's own chance of this, stated with the estimate: 60%; at least 1.1-fold (0.05 log units) between middle value and limit.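

In this assay compound 4 gives a limit and not a number, as compound 3 does, so exchanging 1H-pyrazol-3-yl for 4H-1,2,4-triazol-4-yl leaves the read-out at the same limit: the limit of > 250 mg/kg in this assay, at which 2 of the 4 values shown sit.

This shows that, on this aromatic carbon, para to a hydroxy group, a ring without a hydrogen-bond donor gives no number any more than the ring with one does, and the steps from compound 3 and from compound 1 to compound 4 cannot be read. Among the compounds shown here, the only readable comparison is an at least 1.2-fold higher number from compound 2 to compound 4 (0.09 log units; that floor lies within the scatter), so this assay does not separate the two rings attached through nitrogen, 1H-pyrazol-1-yl and 4H-1,2,4-triazol-4-yl.

As far as these compounds go, how far compound 3 and compound 4 actually lie beyond their limits stays open, and so does any order among the rings that reach a limit. Also open, from the compounds shown here alone, is whether a group of another kind at this place, such as a phenyl ring or a carboxamide, would give a number clearly apart from that of compound 2.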